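Cyclobutyl Replaces Isopropyl on the Sulfonamide Nitrogen

The source may hold more compounds than are shown below. What is called first, only, known or untested is meant among the compounds shown, and "the series" means these compounds.

Among the compounds with values here, compound 2 `CC(C)NS(=O)(=O)c1ccc(S(=O)(=O)N2CCC[C@@H](C(=O)N3CCN(c4nc(C(C)C)no4)CC3)C2)cc1` is one of two compounds measured in a functional assay on MIA PaCa-2 cells (Homo sapiens) for inhibition, read by MTT assay, with a stated time of 7 days; on this read-out higher numbers stand for weaker inhibition and lower numbers for stronger inhibition. In this assay compound 2 gives 2600 nM, the higher of the two numbers. Within the data shown here, its only neighbour, compound 1 `CC(C)c1noc(N2CCN(C(=O)[C@@H]3CCCN(S(=O)(=O)c4ccc(S(=O)(=O)NC5CC5)cc4)C3)CC2)n1`, differs solely on a sulfonamide nitrogen, and in this assay compound 1 gives 1000 nM. Among the measured compounds shown here, the single measured step, a 2.6-fold higher number from compound 1 to compound 2 (0.41 log units; beyond the scatter), is the only change that bears on the next move: swapping cyclopropyl for isopropyl raised the number modestly. Compound 3 `CC(C)c1noc(N2CCN(C(=O)[C@@H]3CCCN(S(=O)(=O)c4ccc(S(=O)(=O)NC5CCC5)cc4)C3)CC2)n1` changes the same position again: cyclobutyl in place of isopropyl on a sulfonamide nitrogen. The entering group is once more a small carbon ring, as in compound 1, so a partial return toward the number of compound 1 is expected, though cyclobutyl is not cyclopropyl and one step is a thin basis. For compound 3 the expected result in this assay is 1500 nM, estimated to lie between 600 nM and 4000 nM, an expected step of a 1.7-fold lower number from compound 2 to compound 3 (0.24 log units; within the scatter).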

Compound 3, half-maximal inhibitory concentration: 600 nM
The estimate for compound 3 lay 2.5-fold (0.40 log units) above the measured number; measured number inside the range.
By their numbers in this assay, from the lowest: compounds 3 and 1 (each within the scatter of the next); then compound 2.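

In this assay cyclobutyl in place of isopropyl on the sulfonamide nitrogen gives a 4.3-fold lower number from compound 2 to compound 3 (0.64 log units; beyond the scatter) and so shows that this position responds to a second ring as well as to cyclopropyl. Cyclobutyl in place of cyclopropyl gives a 1.7-fold lower number from compound 1 to compound 3 (0.22 log units; within the scatter) and leaves these two ring-bearing compounds indistinguishable here, while compound 2, with isopropyl, the one group without a ring, has the highest number of the three. Nothing measured here explains this pattern.

As far as these compounds go, whether it extends to a larger ring such as cyclopentyl, to an unbranched chain such as n-propyl, or to a nitrogen carrying only hydrogen remains open. These three compounds also say nothing about how changes elsewhere on the shared core would behave.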